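Urea to benzylamine at the aniline nitrogen: cytotoxicity outlook

A few compounds are considered here, and "the series" means these few. Any claim that something is new, unique, unknown or untested is made for them only; others in the source may bear on it.

Measured compounds:
- compound 1, `Cc1ccc(-c2c(C)c(-c3ccc(C)c(C)c3)c(C(OC(C)(C)C)C(=O)O)c(C)c2NC(=O)Nc2ccccc2)cc1C`: 8000 nM
- compound 2, `Cc1ccc(-c2c(C)c(-c3ccccc3)c(C(OC(C)(C)C)C(=O)O)c(C)c2NS(C)(=O)=O)cc1C`: > 50000 nM
- compound 3, `Cc1ccc(-c2c(C)c(-c3ccc4c(c3)CCCO4)c(C(OC(C)(C)C)C(=O)O)c(C)c2NS(C)(=O)=O)cc1C`: 28000 nM

In an ADME assay on MT4 cells (Homo sapiens) for cytotoxicity, read by MTT assay, with a stated time of 4 days (on this read-out higher numbers stand for lower toxicity in this test and lower numbers for higher toxicity in this test), compound 1 gives 8000 nM, the lowest of the two numbers that are not limits; compound 3 sits nearest with 28000 nM, a gap beyond the scatter. Compound 2 reaches only the assay limit of > 50000 nM, which is a limit and not a number (the limit of > 50000 nM in this assay, at which 1 of the 3 values shown sits). Among the measured compounds shown here, the one measured step, an at least 1.7-fold lower number from compound 2 to compound 3 (0.25 log units; that floor lies within the scatter), concerns a change at the aromatic carbon bearing the aryl ring, not the nitrogen, so it does not bear on the change now considered.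

Compound 4, `Cc1ccc(-c2c(C)c(-c3ccc(C)c(C)c3)c(C(OC(C)(C)C)C(=O)O)c(C)c2NCc2ccccc2)cc1C`, differs from compound 1 by benzyl in place of phenylcarbamoyl on a nitrogen on an aromatic ring. For the measured compounds named here, no measured pair addresses this change, so the expectation rests on compound 1 alone and no step beyond the scatter is assumed; the step is estimated as a 1.3-fold higher number from compound 1 to compound 4 (0.10 log units; within the scatter). Compound 4 is thus expected to give about 10000 nM in this assay, with a range from 3000 nM to 35000 nM.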

Compound 4, half-maximal cytotoxic concentration: 4000 nM
Beside the measured number, compound 4's estimate is 2.5-fold (0.40 log units) above it; the measured number falls inside the stated range.
By their numbers in this assay, from the lowest: compounds 4 and 1 (each within the scatter of the next); then compound 3. At a limit, above all of these: compound 2.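

At the nitrogen on an aromatic ring, this assay now gives a direct comparison: a 2.0-fold lower number from compound 1 to compound 4 (0.30 log units; within the scatter). This exchange of phenylcarbamoyl, which has a carbonyl and counts a hydrogen-bond donor and acceptor, for benzyl, which has neither, therefore stays within the usual scatter, so the read-out in this test is not tied to phenylcarbamoyl at this position. Nothing shown here offers a cause for this step.

This single pair leaves open how other groups on the same nitrogen would read, such as methyl, acetyl or a benzyl carrying a carboxylic acid. It also leaves open whether benzyl in place of phenylcarbamoyl would read the same way with a different aryl group on the shared core.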